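This account rests on a few compounds, and the source may have more. Where it says the series, first, only, none or still open, it means among the compounds named here.

The series was examined in a functional assay on COLO 205 cells (Homo sapiens) for inhibition, read by sulforhodamine B assay, with a stated time of 48 h, tested at 50 uM; on this read-out higher numbers stand for more inhibition of growth at the one concentration tested and lower numbers for less inhibition of growth. Compound 1, with the structure `COc1ccccc1/C=C/C(=O)/C=C/c1ccc(OCc2cn(CCCCOc3cc(=O)oc4ccccc34)nn2)c(OC)c1`, gives 47% in this assay, the lowest of the three numbers in hand. Compound 2, `COc1cc(/C=C/C(=O)/C=C/c2cccc3ccccc23)ccc1OCc1cn(CCCOc2cc(=O)oc3ccccc23)nn1`, gives 64% in this assay, a number beyond the scatter above that of compound 1, and compound 3, `COc1ccc(/C=C/C(=O)/C=C/c2ccc(OCc3cn(CCOc4cc(=O)oc5ccccc45)nn3)c(OC)c2)cc1`, gives 68% in this assay, further above still. Compounds 2 and 3 differ from compound 1 in more than one place, so their values show only that other arrangements of this kind of molecule can reach higher growth inhibition. Compound 4, `COc1cccc(/C=C/C(=O)/C=C/c2ccc(OCc3cn(CCCCOc4cc(=O)oc5ccccc45)nn3)c(OC)c2)c1`, has not yet been measured. Its difference from compound 1 is 3-methoxyphenyl in place of 2-methoxyphenyl on a double-bonded chain carbon bound to a double-bonded chain carbon. Among the measured compounds shown here, no single-change step between measured compounds exists to calibrate such a move of the methoxy group, so its direction is uncertain. Compound 4 is expected to give about 55% in this assay, with a plausible range from 35% to 75%. The step that this estimate means, a number 8 percentage points higher from compound 1 to compound 4 (within the scatter), is expected to stay within the scatter. The slight upward lean rests on compound 2 giving 64% and compound 3 giving 68%, both higher than compound 1.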

Compound 4, percent growth inhibition at one concentration: 46%
Beside the measured number, compound 4's estimate is 9 percentage points above it; the range from low to high includes it.
By their numbers in this assay, from the lowest: compounds 4 and 1 (each within the scatter of the next); then compounds 2 and 3 (each within the scatter of the next).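

In this assay, 3-methoxyphenyl in place of 2-methoxyphenyl on a double-bonded chain carbon bound to a double-bonded chain carbon gives a number 1 percentage points lower from compound 1 to compound 4 (within the scatter). Among the compounds shown here, this is the first single-change step, and it shows that, at the one concentration tested, this read-out does not separate these two methoxyphenyl groups at this place. Nothing in hand speaks to why the two compounds read alike.

Steps from compound 1 or compound 4 to compounds 2 and 3 cannot be read, since those pairs differ in more than one place, so the separate contribution of each of their differences stays unknown. Also open, going by these compounds, is whether a different group at this place, such as an amine or a carboxylic acid, would shift growth inhibition beyond the scatter.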